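Cytotoxicity notes: urea in place of carbamate on the chain

A few compounds are considered here, and "the series" means these few. Any claim that something is new, unique, unknown or untested is made for them only; others in the source may bear on it.

Measured so far:
compound 1 `Cc1nc(NCC2CCC2)nc(N[C@@H]2C[C@H](CO)[C@@H](O)[C@H]2O)c1-c1nc2ccccc2s1` gives > 25000 nM
compound 2 `CCOC(=O)NCCNc1nc(C)c(-c2nc3ccccc3s2)c(N[C@@H]2C[C@H](CO)[C@@H](O)[C@H]2O)n1` gives 12000 nM

Among the measured compounds shown here, in an ADME assay on cells (Homo sapiens) for cytotoxicity, read by polymerase chain reaction, with a stated time of 3 days (a higher number here means that more compound is tolerated, a lower number that less compound is tolerated), compound 2 gives 12000 nM, the only number in the set. For compound 1 the result is a limit of the assay, namely (the limit of > 25000 nM in this assay, at which 1 of the 2 values shown sits). For the measured compounds named here, the one measured step, an at least 2.0-fold lower number from compound 1 to compound 2 (0.31 log units; beyond the scatter), alters a different part of the side chain. Compound 3 `Cc1nc(NCCNC(=O)NC(C)(C)C)nc(N[C@@H]2C[C@H](CO)[C@@H](O)[C@H]2O)c1-c1nc2ccccc2s1` carries (tert-butyl)amino in place of ethoxy on a carbonyl carbon. Going by the values given here, no measured step covers this change, so no step beyond the scatter is expected; the estimated step for compound 3 is no change at the digits printed from compound 2 to compound 3 (within the scatter). For compound 3 the expected value is 12000 nM, within 5000 nM to 30000 nM.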

Compound 3, half-maximal cytotoxic concentration: > 25000 nM
Compound 3: a limit, no number; the forecaster's own chance of this, stated with the estimate: 30%; middle value at least 2.0-fold (0.31 log units) away from the limit.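

With (tert-butyl)amino in place of ethoxy on a carbonyl carbon, the series shows an at least 2.0-fold higher number from compound 2 to compound 3 (0.31 log units; beyond the scatter), so a change at this place alone moves the result. In this assay compound 3 gives > 25000 nM, which is a limit of the assay and not a number. The step from compound 1 to compound 3 cannot be read, and the series now meets this ceiling twice: the limit of > 25000 nM in this assay, at which 2 of the 3 values shown sit.

On these data alone, how far compound 3 lies past its limit stays open. Also open, as far as these compounds go, is whether the lower number of compound 2 goes with ethoxy specifically; a methylamino group on a carbonyl carbon would bear on that.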